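The source may hold more compounds than are shown below. What is called first, only, known or untested is meant among the compounds shown, and "the series" means these compounds.

Three compounds built on the core of compound 1 `Cc1cc(NC(C)C)nc(SCc2nc3ccccc3[nH]2)n1` have so far been tested in a functional assay on PC-3 cells (Homo sapiens) for cytotoxicity, read by MTT assay, with a stated time of 72 h; a higher number here means a weaker inhibitor, a lower number a stronger inhibitor. For compound 1 the result is only a limit of the assay, > 100000 nM. Compound 2 `Cc1cc(NCCO)nc(SCc2nc3ccccc3[nH]2)n1` carries 2-hydroxyethyl in place of isopropyl on a nitrogen on an aromatic ring, and compound 2 likewise reaches only a limit, > 100000 nM. Compound 3 `COc1ccccc1Nc1cc(C)nc(SCc2nc3ccccc3[nH]2)n1` carries 2-methoxyphenyl on that nitrogen, and in this assay compound 3 gives 70800 nM. Because two of the values sit at the limit of > 100000 nM in this assay, at which 2 of the 3 values shown sit, the step that the two limits leave unreadable from compound 1 to compound 2 cannot be read, while the steps of an at least 1.4-fold lower number from compound 1 to compound 3 (0.14 log units; that floor lies within the scatter) and an at least 1.4-fold lower number from compound 2 to compound 3 (0.14 log units; that floor lies within the scatter) are known only as floors that lie within the scatter.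

Compound 4 `Cc1cc(N(C)Cc2ccccc2)nc(SCc2nc3ccccc3[nH]2)n1` has not been measured. It differs from compound 1 in one place: benzyl(methyl)amino in place of isopropylamino on an aromatic carbon. Going by the values given here, the one measured step that bears on this change is the one from compound 1 to compound 3, where an aromatic ring entering on that nitrogen went with a number at least slightly lower, though the floor stays within the scatter. A similar small move is expected here, so compound 4 is estimated at 50000 nM, within a range from 15000 nM to 100000 nM. That estimate means a step of an at least 2.0-fold lower number from compound 1 to compound 4 (0.30 log units; that floor lies within the scatter), which may well not exceed the scatter.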

Compound 4, half-maximal inhibitory concentration: > 100000 nM
Compound 4 gave a limit, no number; the forecaster's own chance of this, stated with the estimate: 40%; middle value at least 2.0-fold (0.30 log units) away from the limit.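

Compound 4 shows that an aromatic ring in the amino group at this position does not by itself give a measurable value in this assay, since its benzyl(methyl)amino group carries such a ring and its result is still only a limit of the assay. Replacing the (2-methoxyphenyl)amino group with benzyl(methyl)amino gives an at least 1.4-fold higher number from compound 3 to compound 4 (0.14 log units; that floor lies within the scatter), so this change cannot be told apart from the usual scatter. The steps to compound 4 from compound 1 and from compound 2 cannot be read, because both ends of each are limits: the limit of > 100000 nM in this assay, at which 3 of the 4 values shown sit.

From the compounds shown here alone, whether the ring must sit directly on the nitrogen, or whether the methoxy group of compound 3 matters, stays open. A plain phenylamino group or a benzylamino group that keeps the hydrogen on the nitrogen would bear on both questions.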